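A few compounds are considered here, and "the series" means these few. Any claim that something is new, unique, unknown or untested is made for them only; others in the source may bear on it.

Compound 1 `CC1(C)c2[nH]nc(NC(=O)c3ccc(F)cc3)c2CN1C(=O)C1CCN(C2CC2)CC1`: 380 nM
Compound 2 `CN1CCC(C(=O)N2Cc3c(NC(=O)c4ccsc4)n[nH]c3C2(C)C)CC1`: 140 nM
Compound 3 `CCN1CCC(C(=O)N2Cc3c(NC(=O)CC(C)C)n[nH]c3C2(C)C)CC1`: 410 nM

In a functional assay on A2780 cells (Homo sapiens) for antiproliferative activity, read by fluorescence, with a stated time of 72 h (a lower number here means a stronger inhibitor, a higher number a weaker inhibitor), compound 3 gives 410 nM, the highest of the three numbers, although it lies within the scatter of compound 1 at 380 nM. Compound 2 gives 140 nM, a lower number than that of compound 3 and beyond the scatter.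

The next compound, compound 4 `CC(C)CC(=O)Nc1n[nH]c2c1CN(C(=O)C1CCN(C3CC3)CC1)C2(C)C`, keeps the rest of compound 3 and carries cyclopropyl in place of ethyl on an amine nitrogen in a ring. For the measured compounds named here, no two measured compounds differ in one place, so the size of this step has no direct precedent in the data. Compound 1 carries the same cyclopropyl on a different amide and gives 380 nM, which offers no sign of a large shift in this assay. The estimated step, a 1.2-fold lower number from compound 3 to compound 4 (0.07 log units; within the scatter), would therefore stay within the scatter, slightly towards a lower number if it shows at all. For compound 4 the expected value is 350 nM, with an estimated range from 150 nM to 800 nM.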

Compound 4, half-maximal inhibitory concentration in the A2780 assay: 320 nM
The estimate for compound 4 lay 1.1-fold (0.04 log units) above the measured number, and the stated range covers the measured number.
By their numbers in the A2780 assay, from the lowest: compound 2; then compounds 4, 1 and 3 (each within the scatter of the next).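

For the compounds shown here, in the A2780 assay, cyclopropyl in place of ethyl on an amine nitrogen in a ring gives the first direct reading of this position, a 1.3-fold lower number from compound 3 to compound 4 (0.11 log units; within the scatter) so this change brings no shift that can be told from the scatter. With that cyclopropyl kept, isobutyl in place of 4-fluorophenyl on a carbonyl carbon gives a 1.2-fold lower number from compound 1 to compound 4 (0.07 log units; within the scatter) so this second change also leaves the number within the scatter. In a physicochemical assay for solubility, at pH 7 (on this read-out lower numbers stand for lower solubility and higher numbers for higher solubility), compound 3 gives > 225000 nM and this is a limit of the assay. In the physicochemical assay compound 4 gives > 225000 nM and this too is a limit of the assay. In the physicochemical assay the step from ethyl to cyclopropyl cannot be read, as both values are limits of the assay: the limit of > 225000 nM in the physicochemical assay, at which 2 of the 2 values shown sit.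

On these data alone, whether a benzyl group or a bare hydrogen on this amine nitrogen would move the number in the A2780 assay stays open. Compound 2 differs from each of the others in more than one place, so these pairs do not tie its number to any single group.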